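The source may hold more compounds than are shown below. What is called first, only, known or untested is meant among the compounds shown, and "the series" means these compounds.

Compound 3 `CNC(=O)c1cccc2c1CCC2c1ncc[nH]1` gives 2200 nM in a functional assay on CHO cells for agonist activity at Alpha-1A adrenergic receptor (Homo sapiens), read by FLIPR and calcium flux (on this read-out lower numbers stand for an effect already at smaller amounts and higher numbers for an effect only at larger amounts of compound), and so stands highest of the three measured numbers. Its nearest neighbour is compound 2 `c1cncc(-c2cccc3c2CCC3c2ncc[nH]2)c1`, which gives 2060 nM; the step of a 1.1-fold higher number from compound 2 to compound 3 (0.03 log units; within the scatter) lies within the scatter. Furthest away is compound 1 `Cn1nccc1-c1cccc2c1CCC2c1ncc[nH]1`, which gives 278 nM. Both steps away from compound 1 were of similar size: a 7.4-fold higher number from compound 1 to compound 2 (0.87 log units; beyond the scatter) and a 7.9-fold higher number from compound 1 to compound 3 (0.90 log units; beyond the scatter).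

Compound 4 `c1cc(-c2cn[nH]c2)c2c(c1)C(c1ncc[nH]1)CC2` differs from compound 3 in one place: 1H-pyrazol-4-yl in place of methylcarbamoyl on an aromatic carbon. For the measured compounds named here, the step that bears most on this is the one from compound 1 to compound 3, where a pyrazole left and methylcarbamoyl entered and the number rose, a 7.9-fold higher number from compound 1 to compound 3 (0.90 log units; beyond the scatter); reversing that direction, a pyrazole entering in place of methylcarbamoyl is expected to lower the number, though the pyrazole here is attached through a different ring atom and carries no methyl group, so the full size of that step need not return. A smaller step is therefore expected for a 3.1-fold lower number from compound 3 to compound 4 (0.50 log units; beyond the scatter). For compound 4 in this assay the estimate is 700 nM, with a range from 200 nM to 2500 nM.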

Compound 4, half-maximal effective concentration: 14 nM
The estimate for compound 4 lay 50-fold (1.70 log units) above the measured number; measured number below the stated range.
By their numbers in this assay, from the lowest: compound 4; then compound 1; then compounds 2 and 3 (each within the scatter of the next).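

In this assay, the earlier groups at this aromatic carbon had differed only modestly, but 1H-pyrazol-4-yl stands well apart from two of them: a 160-fold lower number from compound 3 to compound 4 (2.20 log units; beyond the scatter) and a 150-fold lower number from compound 2 to compound 4 (2.17 log units; beyond the scatter). The two pyrazoles are not interchangeable either, with a 20-fold lower number from compound 1 to compound 4 (1.30 log units; beyond the scatter), so having a five-membered aromatic ring with two hetero atoms at this carbon does not by itself set the number. Nothing measured here accounts for this result.

The step between the two pyrazoles changes both the attachment atom and the methyl group, so the compounds shown leave open which of these carries it, a question that 1-methyl-1H-pyrazol-4-yl could help to separate. They also leave open how an imidazol-4-yl ring or a simple amine would compare at this carbon.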